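Adding a Chloro Group to an Acetylsulfonamide Pyrazole

The compounds below may be only part of what the source reports. "The series", "measured", "known", "first", "only" and "open" are said of these compounds alone.

Of the compounds shown here, two of a shared core have been measured in a functional assay on cells (Leukemia cell, Homo sapiens) for cytotoxicity, read by sulforhodamine B assay, with a stated time of 48 h; on this read-out higher numbers stand for weaker inhibition of growth and lower numbers for stronger inhibition of growth. Compound 1 `COc1ccc(OC)c(-c2cc(-c3ccc(Cl)cc3)nn2-c2ccccc2)c1` gives 78200 nM in this assay. Compound 2 `COc1ccc(OC)c(-c2cc(-c3ccccc3)nn2-c2ccc(S(=O)(=O)NC(C)=O)cc2)c1` gives 53400 nM in this assay, and on these numbers compound 2 sits alongside compound 1, the gap between the two lying within the usual scatter, so neither can be called the more active. Compound 3 `COc1ccc(OC)c(-c2cc(-c3ccc(Cl)cc3)nn2-c2ccc(S(=O)(=O)NC(C)=O)cc2)c1` has not yet been measured in this assay. It differs from compound 2 by chloro in place of hydrogen on an aromatic carbon, so that the phenyl on the core becomes a 4-chlorophenyl. Within the data shown here, no measured pair shows this change directly; compound 1 carries the same chloro group but also differs elsewhere, so it only shows that both substitution patterns give numbers of a similar size. The step from compound 2 to compound 3 is therefore expected to be small, with no direction beyond the scatter, as the estimated step of a 1.0-fold higher number from compound 2 to compound 3 (0.01 log units; within the scatter) shows. In this assay compound 3 is expected to give about 55000 nM, within a range from 22000 nM to 140000 nM.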

Compound 3, concentration for total growth inhibition: 50100 nM
For compound 3 the middle estimate is 1.1-fold (0.04 log units) above the measured one; measured number inside the range.
By their numbers in this assay, from the lowest: compounds 3, 2 and 1 (each within the scatter of the next).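

Among these compounds, compound 3 gives the first direct reading of chloro in place of hydrogen at this position, para to a large group on the phenyl: in this assay the change gives a 1.1-fold lower number from compound 2 to compound 3 (0.03 log units; within the scatter). Among the compounds shown here, it also gives the first direct reading of the acetylsulfamoyl group on the other aromatic ring, with a 1.6-fold lower number from compound 1 to compound 3 (0.19 log units; within the scatter), so neither single change shifts the number beyond the scatter when the other group is present. No measurement is at hand that would account for these small steps.

What the compounds shown leave open is whether another group at the same position, such as an amine, a carboxylic acid or a longer chain, would give a step beyond the scatter. They also leave open whether chloro would behave the same way on a core carrying a different group in place of acetylsulfamoyl.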